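Swapping isopropyl for difluoromethyl on the alkoxy oxygen

The source may report more compounds than this note shows. Statements on the series, on what has been measured and on what is new or still open speak of the compounds shown alone.

Measured so far in an ADME assay on the whole organism (Mus musculus, strain CD-1) for pharmacokinetics; on this read-out lower numbers stand for slow clearance and higher numbers for fast clearance
compound 1 (`CCOc1cc([C@](O)(CCN(C)C)[C@@H](c2cc3cc(Br)ccc3nc2OC)c2cccc(OC)c2F)cc(OC)n1`) 19 mL/min/kg
compound 2 (`COc1cc([C@](O)(CCN(C)C)[C@@H](c2cc3cc(Br)ccc3nc2OC)c2cccc(OC)c2F)cc(OC(C)C)n1`) 8.9 mL/min/kg
compound 3 (`COc1cc([C@](O)(CCN(C)C)[C@@H](c2cc3cc(Br)ccc3nc2OC)c2ccnc(OC)c2OC)cc(OC(C)C)n1`) 6.8 mL/min/kg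

Compound 2 lies within the scatter of compound 3 and beyond the scatter below compound 1. Compound 4 (`COc1cc([C@](O)(CCN(C)C)[C@@H](c2cc3cc(Br)ccc3nc2OC)c2cccc(OC)c2F)cc(OC(F)F)n1`) is compound 2 with difluoromethyl in place of isopropyl on an oxygen on an aromatic ring. The most relevant evidence is a 2.1-fold lower number from compound 1 to compound 2 (0.33 log units; beyond the scatter), which alters the group on that same oxygen. The other measured change, a 1.3-fold lower number from compound 2 to compound 3 (0.12 log units; within the scatter), replaces a different group and bears little on this question. Within the data shown here, no measured compound carries difluoromethyl on that oxygen, so the direction remains uncertain. Given a 2.1-fold lower number from compound 1 to compound 2 (0.33 log units; beyond the scatter) as the only guide to how far this group can move the read-out, a small rise is expected, no larger than that modest step. The expected change is a 1.3-fold higher number from compound 2 to compound 4 (0.13 log units; within the scatter) in this assay here. For compound 4 the estimated clearance is 12 mL/min/kg with an expected range from 6 mL/min/kg to 24 mL/min/kg in this series.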

Compound 4, clearance: 9.7 mL/min/kg
Estimate against measurement, compound 4: 1.2-fold (0.09 log units) above; the measured number falls inside the stated range.
By their numbers in this assay, from the lowest: compounds 3, 2, 4 and 1 (each within the scatter of the next, the first and the last beyond it).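

In this assay, difluoromethyl and isopropyl on this oxygen cannot be told apart, with a 1.1-fold higher number from compound 2 to compound 4 (0.04 log units; within the scatter), so the carbon count of the group is not decisive between these two. Against ethyl, a 2.0-fold lower number from compound 1 to compound 4 (0.29 log units; within the scatter) also stays within the scatter, though only just, whereas a 2.1-fold lower number from compound 1 to compound 2 (0.33 log units; beyond the scatter) lies beyond it, leaving compound 4 unresolved from both neighbours and the group's influence at this position still modest across compounds 1, 2 and 4. Nothing available accounts for the match between difluoromethyl and isopropyl.

Open, going by these compounds, is whether trifluoromethyl, cyclopropyl or a longer chain on this oxygen would stay in the same narrow band or leave it. Also open, on these data alone, is whether difluoromethyl behaves the same way alongside the 2,3-dimethoxypyridin-4-yl group of compound 3.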